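Working notes on four amides, cytotoxicity

The compounds below may be only part of what the source reports. "The series", "measured", "known", "first", "only" and "open" are said of these compounds alone.

Compound 1 `COc1ccc(CNC(=O)CSc2nc3ccc(NC(=O)c4ccc(Cl)cc4)cc3s2)cc1` and compound 2 `O=C(CSc1nc2ccc(NC(=O)c3ccc(Cl)cc3)cc2s1)NCc1ccc(Cl)cc1` share one core; compound 3 `COc1ccc(CNC(=O)CSc2nc3ccc(NC(C)=O)cc3s2)cc1` and compound 4 `CC(=O)Nc1ccc2nc(SCC(=O)NCc3ccc(Cl)cc3)sc2c1` share another. The two cores differ by methyl in place of 4-chlorophenyl on a carbonyl carbon. In a functional assay on MCF7 cells (Homo sapiens) for cytotoxicity, read by MTT assay, with a stated time of 48 h (on this read-out lower numbers stand for stronger inhibition and higher numbers for weaker inhibition), compound 1 gives 19200 nM, compound 2 gives 29300 nM and compound 3 gives 20500 nM. Between compound 1 and compound 2 the change is chloro in place of methoxy on an aromatic carbon; in this assay this made a 1.5-fold higher number from compound 1 to compound 2 (0.18 log units; within the scatter). Across the core change, a 1.1-fold higher number from compound 1 to compound 3 (0.03 log units; within the scatter).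

Compound 4 has not yet been measured. It differs from compound 3 by chloro in place of methoxy on an aromatic carbon, the same change as between compound 1 and compound 2, with the same surroundings at the place. For the measured compounds named here, the only guide is that a 1.5-fold higher number from compound 1 to compound 2 (0.18 log units; within the scatter) stayed within the scatter, as did a 1.1-fold higher number from compound 1 to compound 3 (0.03 log units; within the scatter). The expected step in this assay is therefore a 1.3-fold higher number from compound 3 to compound 4 (0.12 log units; within the scatter), likewise within the scatter. For compound 4 the estimated value in this assay is 27000 nM, with an expected range from 13000 nM to 55000 nM. Two measured steps underlie this; whether the swap behaves alike on both cores rests on a single comparison.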

Compound 4, half-maximal inhibitory concentration: 10200 nM
Compound 4: the middle estimate sits 2.6-fold (0.42 log units) above what was measured; the whole stated range lies above it.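

On the second core, chloro in place of methoxy gives a 2.0-fold lower number from compound 3 to compound 4 (0.30 log units; within the scatter), and this step does not match the one on the first core: the same change on two cores in this assay, a 1.5-fold higher number (0.18 log units; within the scatter) from compound 1 to compound 2 and a 2.0-fold lower number (0.30 log units; within the scatter) from compound 3 to compound 4, 3.1-fold (0.49 log units) apart, beyond the scatter of two such steps. Methyl in place of 4-chlorophenyl on the carbonyl carbon, read with chloro on the other aromatic ring, gives a 2.9-fold lower number from compound 2 to compound 4 (0.46 log units; beyond the scatter), and this step does not match its counterpart with methoxy in that place: the same change on two cores in this assay, a 1.1-fold higher number (0.03 log units; within the scatter) from compound 1 to compound 3 and a 2.9-fold lower number (0.46 log units; beyond the scatter) from compound 2 to compound 4, 3.1-fold (0.49 log units) apart, beyond the scatter of two such steps. In this assay, for the compounds shown here, neither change therefore carries over as a fixed step within this set, but four compounds form only a single comparison and show neither why the steps part nor whether the mismatch holds elsewhere.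

Other groups in place of methoxy and chloro, such as fluoro, hydroxyl or a dimethylamino group, remain open, as does a longer chain in place of methyl on the carbonyl carbon. Whether the two cores would still part with such groups cannot be told from these compounds.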